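This account rests on a few compounds, and the source may have more. Where it says the series, first, only, none or still open, it means among the compounds named here.

Four compounds share one core and differ only in the group attached to a single aromatic carbon of that core. Compound 1 `Nc1ccnc(-c2nn(Cc3ccccc3F)c3ncccc23)n1` carries nothing but hydrogen there; in a functional assay (aorta) with Oryctolagus cuniculus as the target (a higher number here means a weaker inhibitor, a lower number a stronger inhibitor), compound 1 gives 270 nM; 265000 nM (2 entries), two entries so far apart that no single number can stand for it. Compound 2 `CCCCc1cnc(-c2nn(Cc3ccccc3F)c3ncccc23)nc1N` carries a butyl group, and in this assay compound 2 gives 218000 nM. Among the measured compounds shown here, compound 3 `Nc1nc(-c2nn(Cc3ccccc3F)c3ncccc23)ncc1C1CCCCC1` carries a cyclohexyl group, and in this assay compound 3 gives 561000 nM, the higher of the two single numbers so far; the step of a 2.6-fold higher number from compound 2 to compound 3 (0.41 log units; beyond the scatter) is modest but beyond the scatter. Compound 4 `CS(=O)(=O)c1cnc(-c2nn(Cc3ccccc3F)c3ncccc23)nc1N` has not yet been measured. It differs from compound 3 in this way: methylsulfonyl in place of cyclohexyl on an aromatic carbon. For the measured compounds named here, the only measured step at this carbon exchanged one carbon group for another, and no measured step brings in a methylsulfonyl group. The two entries of compound 1 the several entries of compound 1 in this assay, 270 nM; 265000 nM (2 entries) show how widely a single measurement here can swing. Compound 4 is therefore expected to remain in the same weak range as compounds 2 and 3, with the expected step of a 2.8-fold lower number from compound 3 to compound 4 (0.45 log units; beyond the scatter) small and toward a lower number. The estimate for compound 4 is 200000 nM, with a range from 20000 nM to 1000000 nM.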

Compound 4, half-maximal inhibitory concentration: 261000 nM
Compound 4: middle estimate off by 1.3-fold (0.12 log units), on the low side; measured number inside the range.
By their numbers in this assay, from the lowest: compounds 2 and 4 (each within the scatter of the next); then compound 3.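

Methylsulfonyl is the only group shown at this aromatic carbon that holds oxygen and sulfur rather than carbon alone, and in this assay exchanging cyclohexyl for it gives a 2.1-fold lower number from compound 3 to compound 4 (0.33 log units; beyond the scatter), a modest change. Exchanging butyl for it gives a 1.2-fold higher number from compound 2 to compound 4 (0.08 log units; within the scatter), so these two groups cannot be told apart here, even though one is a plain carbon chain and the other is not. Across the three compounds with a single number, a change in the atoms of the group at this position, ortho to an amino group, therefore moves the number only a little, and cyclohexyl is the only group that stands apart from the others, with all three numbers remaining high.

Among the compounds shown here, whether any of these groups differs from plain hydrogen stays open, and steps to compound 1 cannot be read because its two entries disagree so widely: the several entries of compound 1 in this assay, 270 nM; 265000 nM (2 entries) How an amine, a carboxylic acid or a short chain such as methyl would behave at this carbon also remains unknown, so the flat picture rests on only three groups.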